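This account rests on a few compounds, and the source may have more. Where it says the series, first, only, none or still open, it means among the compounds named here.

Measured compounds:
compound 1, `Cc1cc(C(=O)O)nn1-c1ccc(S(=O)(=O)N2CCC(=O)N(C3CCCCC3)C2=S)cc1`, 2%
compound 2, `CCCCN1C(=O)CCN(S(=O)(=O)c2ccc(-n3nc(C(=O)O)cc3C)cc2)C1=S`, 2%

In a functional assay on the whole organism (blood, strain albino) with Mus musculus as the target, with stated times of 6 days and 3 h, at a dose of 1 mmol/kg by the oral route (on this read-out higher numbers stand for more inhibition at the one dose given (going by the name of the read-out) and lower numbers for less inhibition), compound 1 gives 2% and compound 2 gives 2%, so compound 2 stands level with compound 1 at the digits shown. Among the compounds with values here, the one measured step, no change at the digits printed from compound 1 to compound 2 (within the scatter), alters a group on an amide-type nitrogen in a ring and leaves the read-out where it was. Compound 3, `CCCCN1C(=O)CCN(S(=O)(=O)c2ccc(-n3nc(C)cc3C)cc2)C1=S`, differs from compound 2 at a different place: methyl in place of carboxy on an aromatic carbon. Within the data shown here, no measured step touches this part of the shared core, so the step from compound 1 to compound 2 offers no direct guide here. Both measured compounds sit near the bottom of the scale in this assay, and nothing in the data points to a change beyond the scatter from this swap. Compound 3 is therefore expected to stay low, with an expected step of a number 1 percentage points higher from compound 2 to compound 3 (within the scatter). The estimate for compound 3 in this assay is 3%, with a range from -8% to 15%.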

Compound 3, a percentage reported as inhibition, in the whole organism at one dose (the size of the read-out at that dose, not a potency): 1%
For compound 3 the middle estimate is 2 percentage points above the measured one, within the range that was stated.
By their numbers in this assay, from the lowest: compounds 3, 1 and 2 (each within the scatter of the next).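

Until now, both measured compounds carried carboxy on this aromatic carbon of the five-membered aromatic ring with 2 nitrogen, so the role of that group could not be judged. In this assay, putting methyl in its place gives a number 1 percentage points lower from compound 2 to compound 3 (within the scatter) and so leaves the read-out indistinguishable from that of the carboxy compound. Carboxy at this position therefore makes no difference that can be told apart from the usual scatter, and neither group stands out at this single oral dose.

From the compounds shown here alone, whether an amine or an ethyl ester on this same aromatic carbon would move the read-out beyond the scatter stays open. No accompanying measurement offers an explanation for this result.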